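Methoxy Substitution on Pyrazole Chalcones in Breast Cancer Cells

This account rests on a few compounds, and the source may have more. Where it says the series, first, only, none or still open, it means among the compounds named here.

The measured compounds:
Compound 1, `COc1ccc(-c2cc(/C=C/C(=O)c3ccc(N)cc3)[nH]n2)cc1`: 780 nM
Compound 2, `COc1ccc(C(=O)/C=C/c2cc(-c3cc(OC)c(OC)c(OC)c3)n[nH]2)cc1OC`: 820 nM
Compound 3, `COc1ccc(-c2cc(/C=C/C(=O)c3ccc(N)cc3)[nH]n2)cc1OC`: 2280 nM

Of the compounds shown here, three have been tested in a functional assay on MCF7 cells (Homo sapiens) for inhibition, read by sulforhodamine B assay, with a stated time of 48 h; a lower number here means a stronger inhibitor of growth, a higher number a weaker inhibitor of growth. In this assay compound 1 gives 780 nM, compound 2 gives 820 nM, and compound 3 gives 2280 nM. Compound 1 and compound 3 differ in one place, (methoxy in place of hydrogen on an aromatic carbon), and this change made a step of a 2.9-fold higher number from compound 1 to compound 3 (0.47 log units; beyond the scatter). Compound 2 stands with compound 1 within the usual scatter of such measurements, and the difference between the cores of compound 1 and compound 2 is not broken down here.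

Compound 4, `COc1cc(C(=O)/C=C/c2cc(-c3cc(OC)c(OC)c(OC)c3)n[nH]2)cc(OC)c1OC`, has not yet been measured in this assay. It differs from compound 2 by methoxy in place of hydrogen on an aromatic carbon. This is the same kind of change as that from compound 1 to compound 3, but the surroundings are not identical: in compound 4 the entering group sits ortho to a methoxy group and meta to a large group and also meta to a methoxy group, whereas in compound 3 it sits ortho to a methoxy group and meta to a large group only.

Because compound 3 gave 2280 nM after the same kind of change from compound 1, the step from compound 2 to compound 4 is expected to be a 2.3-fold higher number from compound 2 to compound 4 (0.36 log units; beyond the scatter). Compound 4 is therefore estimated at 1900 nM in this assay, with a likely range from 800 nM to 4500 nM.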

Compound 4, concentration for 50% growth inhibition: 640 nM
Beside the measured number, compound 4's estimate is 3.0-fold (0.47 log units) above it, and the stated range ends above it.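

In this assay, methoxy in place of hydrogen on an aromatic carbon gave a 1.3-fold lower number from compound 2 to compound 4 (0.11 log units; within the scatter), so on this core the added group left no effect that can be told from the scatter, and compound 4 stands with compound 2. The loss seen on the core of compound 1 therefore did not carry over to the core of compound 2, and the outcome of this change depended on the core that received it: the same change on two cores in this assay, a 2.9-fold higher number (0.47 log units; beyond the scatter) from compound 1 to compound 3 and a 1.3-fold lower number (0.11 log units; within the scatter) from compound 2 to compound 4, 3.7-fold (0.57 log units) apart, beyond the scatter of two such steps. Among these compounds, this does not show which difference between the cores, or between the surroundings of the entering group, accounts for the gap, and with only one pair on each core it gives no general rule for the series.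

The compounds shown leave open whether the same dependence on the core would appear with other groups on that aromatic carbon, such as a hydroxyl group, a fluorine atom or a longer ether chain like ethoxy. They also leave open how the amine carried by compound 1 and compound 3 would behave if it were replaced by a carboxylic acid or an amide on an otherwise unchanged core.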